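Three Methoxy Groups in Place of One on the Ring Carbon

The source may report more compounds than this note shows. Statements on the series, on what has been measured and on what is new or still open speak of the compounds shown alone.

Of the compounds shown here, two that share one core have been measured in a functional assay on the whole organism for inhibition, with Rattus norvegicus as the target, read by paw edema, with a stated time of 3 h, at a dose of 50 mg/kg by the oral route; on this read-out lower numbers stand for less inhibition and higher numbers for more inhibition at the one dose given (going by the name of the read-out). Compound 1, `CS(=O)(=O)c1ccc(C2=NN(c3ccc(S(N)(=O)=O)cc3)C(c3ccc(Cl)cc3)C2)cc1`, carries a 4-chlorophenyl group on a saturated ring carbon and gives 42.4%. Compound 2, `COc1cccc(C2CC(c3ccc(S(C)(=O)=O)cc3)=NN2c2ccc(S(N)(=O)=O)cc2)c1`, carries a 3-methoxyphenyl group at the same place and gives 38.3%. The step of a number 4.1 percentage points lower from compound 1 to compound 2 (within the scatter) is too small to separate the two results. Compound 2 thus stands at the lower of the two figures on paper, but with the gap to compound 1 inside the scatter the two numbers count as level.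

Compound 3, `COc1cc(C2CC(c3ccc(S(C)(=O)=O)cc3)=NN2c2ccc(S(N)(=O)=O)cc2)cc(OC)c1OC`, changes that same position once more: 3,4,5-trimethoxyphenyl in place of 3-methoxyphenyl on a saturated ring carbon. Within the data shown here, the only measured step that bears on this change is the one from compound 1 to compound 2, which also swapped one aryl group for another on that saturated ring carbon and stayed inside the scatter. On that evidence the step of a number 0.3 percentage points lower from compound 2 to compound 3 (within the scatter) is expected to be no larger than the scatter, with no direction favoured. Compound 3 is estimated to give 38% in this assay, in a range from 25% to 51%.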

Compound 3, a percentage reported as inhibition, in the whole organism at one dose (the size of the read-out at that dose, not a potency): 73.7%
For compound 3 the middle estimate is 35.7 percentage points below the measured one; measured number outside the range, above it.
By their numbers in this assay, from the lowest: compounds 2 and 1 (each within the scatter of the next); then compound 3.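

In this assay, the saturated ring carbon that looked indifferent to its aryl group now shows a clear response: the change to 3,4,5-trimethoxyphenyl gives a number 35.4 percentage points higher from compound 2 to compound 3 (beyond the scatter), and set against the 4-chlorophenyl group it gives a number 31.3 percentage points higher from compound 1 to compound 3 (beyond the scatter). The earlier swap between 4-chlorophenyl and 3-methoxyphenyl therefore did not show that all aryl groups at this position behave alike, as the outcome depends on which aryl group sits there, and among these three compounds only compound 3 stands apart. Nothing at hand explains why this group raises the number, and the result is a size of effect at one oral dose and one time, not a potency.

The three compounds cannot tell whether the whole 3,4,5-trimethoxyphenyl pattern is needed or whether part of it would do, which a 3,4-dimethoxyphenyl or 3,5-dimethoxyphenyl group at the same carbon could help to settle. Going by these compounds, it also remains open how this position would respond to an aryl ring carrying a dimethylamino group or a carboxylic acid.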